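The source may report more compounds than this note shows. Statements on the series, on what has been measured and on what is new or still open speak of the compounds shown alone.

Compound 1, with the structure `CCc1cc(C(C)=O)c(O)cc1OCCCCCC(C)(C)C#N`, stands highest of the three compounds measured in an assay on isolated protein for binding affinity to leukotriene B4 receptor 1 (Homo sapiens), tested at 1 uM (a lower number here means less inhibition, a higher number more inhibition at the concentration tested (going by the name of the read-out)), giving 53%. Compound 3, with the structure `C=CCCCCOc1cc(O)c(C(C)=O)cc1CC=C`, is the nearest of the others and gives 27%, and compound 2, with the structure `CC(=O)c1cc(C(C)(C)C)c(OCCCCCC(C)(C)C#N)cc1O`, is the furthest and gives 2%. Among the compounds with values here, the one step between measured compounds that differ in a single place is a number 51 percentage points lower from compound 1 to compound 2 (beyond the scatter), a tert-butyl in place of ethyl on an aromatic carbon, which moved the number a long way.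

Compound 4, with the structure `CCc1cc(C(C)=O)c(O)cc1OCCCCCCc1nnn[nH]1`, has not yet been measured in this assay. It differs from compound 1 in a single place: (1H-tetrazol-5-yl)methyl in place of 1-cyano-1-methylethyl on a saturated chain carbon, five bonds along the chain from an oxygen on an aromatic ring. Within the data shown here, no measured step bears on this change. Among the measured compounds shown here, the only step on record alters a group on an aromatic carbon, while the change from compound 1 to compound 4 alters the end of the saturated chain five bonds from the oxygen on the aromatic ring. The data therefore give no direction for this assay, and the expectation rests on compound 1 alone. Compound 4 is estimated at 45%, within a wide range from 10% to 80%, which means an expected step of a number 8 percentage points lower from compound 1 to compound 4 (within the scatter).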

Compound 4, a percentage reported as inhibition, at one concentration (the size of the read-out at that concentration, not a potency): 60%
Compound 4: the middle estimate sits 15 percentage points below what was measured, and the stated range covers the measured number.
By their numbers in this assay, from the lowest: compound 2; then compound 3; then compounds 1 and 4 (each within the scatter of the next).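

In this assay, the end of the saturated chain, five bonds along from an oxygen on an aromatic ring, accepts a very different group with no change beyond the scatter: putting (1H-tetrazol-5-yl)methyl in place of 1-cyano-1-methylethyl gives a number 7 percentage points higher from compound 1 to compound 4 (within the scatter) in this series. Within the data shown here, a group with no ring and no hydrogen-bond donor thus gives way to a five-membered aromatic ring with 4 hetero atoms and 1 hydrogen-bond donor, and the two compounds remain level, whereas the only earlier step, at an aromatic carbon, was a number 51 percentage points lower from compound 1 to compound 2 (beyond the scatter) and showed nothing about the chain end. No evidence on hand bears on this result.

The compounds shown leave open whether a carboxylic acid or a primary amine at the end of the chain would also stay level with these two groups, and whether a shorter or longer chain carrying (1H-tetrazol-5-yl)methyl would do the same. They also leave open whether tert-butyl in place of ethyl on an aromatic carbon would take as large a step with (1H-tetrazol-5-yl)methyl at the chain end.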